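Acetyl for methoxy on the benzylamide aryl ring

This account rests on a few compounds, and the source may have more. Where it says the series, first, only, none or still open, it means among the compounds named here.

Compound 3 `COc1ccc(CNC(=O)c2ccc(C(C)(C)C)cc2)cc1` gives 150 nM in an assay on HeLa cells with Bile acid receptor (Homo sapiens) as the target, read by a luciferase reporter, with a stated time of 24 h; on this read-out lower numbers stand for an effect already at smaller amounts and higher numbers for an effect only at larger amounts of compound. Among the three measured compounds it holds the second highest number; its nearest neighbour is compound 1 `CC(C)Oc1ccc(CNC(=O)c2ccc(C(C)(C)C)cc2)cc1` with 170 nM, and a 1.1-fold lower number from compound 1 to compound 3 (0.05 log units; within the scatter) lies within the scatter. Compound 2 `CC(C)(C)c1ccc(C(=O)NCc2ccc(NS(C)(=O)=O)cc2)cc1` gives 44 nM and sits furthest away, with a 3.4-fold higher number from compound 2 to compound 3 (0.53 log units; beyond the scatter).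

The next compound, compound 4 `CC(=O)c1ccc(CNC(=O)c2ccc(C(C)(C)C)cc2)cc1`, carries acetyl in place of methoxy on an aromatic carbon. Going by the values given here, no measured step swaps an alkoxy for a carbonyl-bearing group at this position, so the comparison is indirect. Among the compounds with values here, two steps touch the same carbon: a 1.1-fold lower number from compound 1 to compound 3 (0.05 log units; within the scatter) shows that changing the alkyl on the oxygen does nothing beyond the scatter, while a 3.9-fold lower number from compound 1 to compound 2 (0.59 log units; beyond the scatter) and a 3.4-fold higher number from compound 2 to compound 3 (0.53 log units; beyond the scatter) show that exchanging the alkoxy for the methanesulfonamido moves the number modestly downward. Acetyl keeps one hydrogen-bond acceptor and is closer in size to methanesulfonamido than to methoxy, but it has no donor, so a smaller effect is expected. Compound 4 is therefore expected to show a 1.5-fold lower number from compound 3 to compound 4 (0.18 log units; within the scatter), a shift that may or may not exceed the scatter. The estimated value for compound 4 in this assay is 100 nM, within a range from 35 nM to 300 nM.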

Compound 4, half-maximal effective concentration: 100 nM
For compound 4 middle estimate and measured number coincide at the digits printed, and the stated range covers the measured number.
By their numbers in this assay, from the lowest: compound 2; then compounds 4, 3 and 1 (each within the scatter of the next).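

In this assay, acetyl in place of methoxy gives a 1.5-fold lower number from compound 3 to compound 4 (0.18 log units; within the scatter) and acetyl in place of isopropoxy gives a 1.7-fold lower number from compound 1 to compound 4 (0.23 log units; within the scatter), so at this aromatic carbon, para to a large group, acetyl cannot be told apart from either alkoxy group. Against methanesulfonamido the step is a 2.3-fold higher number from compound 2 to compound 4 (0.36 log units; beyond the scatter), which leaves compound 2 as the only compound of the four set apart from all the others by steps beyond the scatter. Nothing measured alongside these numbers bears on the result.

Still open, as far as these compounds go, is which part of methanesulfonamido goes with the lower number, a question that a methylsulfonyl group attached directly to the aromatic carbon, or an acetamido group, would address. From the compounds shown here alone, how an amine or a carboxylic acid at this carbon would read also remains unknown.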